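Swapping Fluorophenyl for Pyridyl: Expected Effect on Solubility

A few compounds are considered here, and "the series" means these few. Any claim that something is new, unique, unknown or untested is made for them only; others in the source may bear on it.

Compound 1 `COc1ccc2[nH]c(C(=O)N3CC(=O)N(Cc4ccccc4)[C@@H](CN4CCC(OC)CC4)C3)cc2c1` and compound 2 `COc1ccc2[nH]c(C(=O)N3CC(=O)N(Cc4ccccc4)[C@@H](CN4CCN(c5ccc(F)cc5)CC4)C3)cc2c1` share a core and were both tested in a physicochemical assay for solubility, read by spectrophotometry, in phosphate buffer, with a stated time of 2 h, at pH 7.4; on this read-out lower numbers stand for lower solubility and higher numbers for higher solubility. Compound 1 reaches a limit of this assay, > 25000 nM. For the measured compounds named here, compound 2 gives 20700 nM, the only plain number among the two values. Of those two values, one is the limit of > 25000 nM in this assay, at which 1 of the 2 values shown sits. Compound 3 `COc1ccc2[nH]c(C(=O)N3CC(=O)N(Cc4ccccc4)[C@@H](CN4CCN(c5ccccn5)CC4)C3)cc2c1` carries pyridin-2-yl in place of 4-fluorophenyl on an amine nitrogen in a ring. Going by the values given here, no step between measured compounds is available, so no measured effect of such a change is known. The expected step from compound 2 to compound 3 is a modest rise, a 1.4-fold higher number from compound 2 to compound 3 (0.16 log units; within the scatter), near the scatter. Compound 3 is estimated at 30000 nM, within 14000 nM to 65000 nM.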

Compound 3, solubility: 30200 nM
For compound 3 the middle estimate is 1.0-fold (0.00 log units) below the measured one; the measured number falls inside the stated range.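

In this assay, pyridin-2-yl in place of 4-fluorophenyl on this amine nitrogen in a ring gives a 1.5-fold higher number from compound 2 to compound 3 (0.16 log units; within the scatter), so the two compounds cannot be told apart on this read-out. An aromatic ring of carbon only and one with a ring nitrogen are therefore both compatible with values of this size at this position. Compound 1 stands at a limit of the assay, and the step from it to compound 3 cannot be read: the limit of > 25000 nM in this assay, at which 1 of the 3 values shown sits.

Going by these compounds, whether a carboxylic acid on the aromatic ring, or an acetyl group directly on this nitrogen, would move the number beyond the scatter stays open. The compounds shown also leave open how pyridin-3-yl would compare with pyridin-2-yl.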